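Swapping the cyclopropyl for a trimethylated piperazine

The source may hold more compounds than are shown below. What is called first, only, known or untested is meant among the compounds shown, and "the series" means these compounds.

Measured compounds:
Compound 1, `CN(C[C@H]1Cc2c(cccc2N2CCN(C3CC3)CC2)CN1)[C@H]1CCCc2cccnc21`: 23.5 nM
Compound 2, `CN(C[C@H]1Cc2c(cccc2N2CCN(c3cccc(C(F)(F)F)c3)CC2)CN1)[C@H]1CCCc2cccnc21`: > 16700 nM

In a functional assay on CCRF-CEM cells for antagonist activity at C-X-C chemokine receptor type 4 (Homo sapiens), read by calcium flux, with stated times of 25 min and 90 s (on this read-out lower numbers stand for stronger inhibition and higher numbers for weaker inhibition), compound 1 gives 23.5 nM. Compound 2, measured in the same setting, reached only a limit of the assay, > 16700 nM, so no exact number is known for it; (the limit of > 16700 nM in this assay, at which 1 of the 2 values shown sits). Among the measured compounds shown here, compound 1 therefore holds the only real number among the two, and the step of an at least 710-fold higher number from compound 1 to compound 2 (2.85 log units; beyond the scatter) shows how much was lost when the cyclopropyl was exchanged for the 3-(trifluoromethyl)phenyl.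

Compound 3, `C[C@@H]1CN(c2cccc3c2C[C@H](CN(C)[C@H]2CCCc4cccnc42)NC3)C[C@H](C)N1C`, has not been measured. It differs from compound 1 in one place: 3,4,5-trimethylpiperazin-1-yl in place of 4-cyclopropylpiperazin-1-yl on an aromatic carbon. Unlike compound 2, it keeps a small, non-aromatic substituent on the piperazine nitrogen, so the large loss seen from compound 1 to compound 2 offers only a weak parallel. The expectation is therefore a step of no more than modest size in this assay, a 1.3-fold higher number from compound 1 to compound 3 (0.11 log units; within the scatter), staying within or close to the scatter. Compound 3 is estimated at 30 nM, with a range from 8 nM to 150 nM.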

Compound 3, half-maximal inhibitory concentration: 14.1 nM
For compound 3 the middle estimate is 2.1-fold (0.33 log units) above the measured one; the measured number falls inside the stated range.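

In this assay the exchange gives a 1.7-fold lower number from compound 1 to compound 3 (0.22 log units; within the scatter) and so leaves the two compounds level. This pair shows that the three-membered ring of the 4-cyclopropylpiperazin-1-yl group is not required for activity here: a 3,4,5-trimethylpiperazin-1-yl group, with the same count of heavy atoms and 2 defined stereocentres, does as well on the same aromatic carbon. The earlier pair showed only a large loss at this place, whereas this one shows that the piperazine can be changed there with no loss beyond the scatter, so the place accepts at least one other non-aromatic group.

Still open, on these data alone, is how much room remains at this place: whether an unsubstituted piperazine, a morpholine ring or a piperazine carrying a longer chain such as n-butyl would hold the number, and whether the 2 defined stereocentres matter at all. The data shown give no measured property that would explain the level result for compound 3.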